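A few compounds are considered here, and "the series" means these few. Any claim that something is new, unique, unknown or untested is made for them only; others in the source may bear on it.

Compound 1, `CN(C(=O)c1ccc(Br)cc1)c1ccc2[nH]c(-c3n[nH]c4ccccc34)cc2n1`: in a functional assay on KB cells (Homo sapiens) for antiproliferative activity, read by MTT assay, with a stated time of 72 h (on this read-out lower numbers stand for stronger inhibition and higher numbers for weaker inhibition), compound 1 gives 1780 nM.
Compound 2, `COc1ccc(C(=O)N(C)c2ccc3[nH]c(-c4n[nH]c5ccccc45)cc3n2)cc1`: compound 2 gives 12900 nM.
Compound 3, `Cc1ccc(S(=O)(=O)N(C)c2ccc3[nH]c(-c4n[nH]c5ccccc45)cc3n2)cc1`: compound 3 gives 9500 nM.

Three compounds share one core and differ only in the group carried on the ring nitrogen bearing the methyl. Compound 3 stands second highest of the three numbers; its nearest neighbour is compound 2, with a 1.4-fold lower number from compound 2 to compound 3 (0.13 log units; within the scatter), while compound 1 sits furthest away, with a 5.3-fold higher number from compound 1 to compound 3 (0.73 log units; beyond the scatter).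

Compound 4, `CN(C(=O)Nc1ccccc1)c1ccc2[nH]c(-c3n[nH]c4ccccc34)cc2n1`, has not yet been measured. It differs from compound 3 in one place: phenylcarbamoyl in place of (4-methylphenyl)sulfonyl on a nitrogen on an aromatic ring. Two of the measured steps touch the same place. The exchange of the acyl group for the sulfonyl group gave a 5.3-fold higher number from compound 1 to compound 3 (0.73 log units; beyond the scatter), whereas the exchange between the methoxy-bearing acyl group and the sulfonyl group gave a 1.4-fold lower number from compound 2 to compound 3 (0.13 log units; within the scatter). Going by the values given here, no measured compound carries a urea at this nitrogen, so the direction of the step cannot be read from the data; the size of the changes seen at this position suggests a modest step at most. Compound 4 is therefore expected to give about 5000 nM in this assay, estimated between 1500 nM and 16000 nM, which would mean a 1.9-fold lower number from compound 3 to compound 4 (0.28 log units; within the scatter).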

Compound 4, half-maximal inhibitory concentration: 32 nM
For compound 4 the middle estimate is 160-fold (2.19 log units) above the measured one, and the stated range ends above it.
By their numbers in this assay, from the lowest: compound 4; then compound 1; then compounds 3 and 2 (each within the scatter of the next).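

In this assay the phenylcarbamoyl group on this nitrogen stands well apart from the sulfonyl group, with a 300-fold lower number from compound 3 to compound 4 (2.47 log units; beyond the scatter) as the result, a far larger move than any earlier exchange at this place had shown. The same holds on the carbonyl carbon, where anilino in place of 4-methoxyphenyl gives a 400-fold lower number from compound 2 to compound 4 (2.61 log units; beyond the scatter) and anilino in place of 4-bromophenyl gives a 56-fold lower number from compound 1 to compound 4 (1.75 log units; beyond the scatter) even though compound 1 had the lowest number of the earlier three, so the choice of group on this carbonyl can matter much more than the first three compounds suggested. Nothing among the data offers an explanation for this gain, and its origin remains unsettled.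

Only one urea is shown, so it remains open whether the gain belongs to the anilino group in particular or would also appear with ethylamino, a methylated anilino or benzyloxy on the same carbonyl. Going by these compounds, it is also open whether bromo or methoxy on the phenyl ring of the anilino group would shift the number as the exchange between them did in the acyl series.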